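The source may report more compounds than this note shows. Statements on the series, on what has been measured and on what is new or still open speak of the compounds shown alone.

Measured so far in a functional assay on SK-N-SH cells (Homo sapiens) for cytotoxicity, read by MTT assay, with a stated time of 24 h; a higher number here means a weaker inhibitor, a lower number a stronger inhibitor:
Compound 1 `C/C(=N\NC(=O)/C(C#N)=C/c1ccc(Br)cc1)c1c(O)c2ccc(O)cc2oc1=O`: 12100 nM
Compound 2 `C/C(=N\NC(=O)/C(C#N)=C/c1ccc(N(C)C)cc1)c1c(O)c2ccc(O)cc2oc1=O`: 6090 nM

Going by the values given here, with only these two numbers available, compound 2 at 6090 nM cannot be separated from its one neighbour. The measured step, a 2.0-fold lower number from compound 1 to compound 2 (0.30 log units; within the scatter), lies within the scatter of this assay. Among the compounds with values here, that step put dimethylamino in place of bromo on an aromatic carbon, and it is the only measured step that bears on what follows.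

The next compound is compound 3 `C/C(=N\NC(=O)/C(C#N)=C/c1ccccc1[N+](=O)[O-])c1c(O)c2ccc(O)cc2oc1=O`, with 2-nitrophenyl in place of 4-(dimethylamino)phenyl on a double-bonded chain carbon bound to a double-bonded chain carbon. Within the data shown here, no measured compound carries 2-nitrophenyl, so the data give no direct reading of this group, and the new substituent also differs from both earlier ones in kind. Among the measured compounds shown here, the single precedent, a 2.0-fold lower number from compound 1 to compound 2 (0.30 log units; within the scatter), gives no reason to expect a step beyond the scatter, and no direction can be firmly assigned. The expected step is a 1.3-fold higher number from compound 2 to compound 3 (0.12 log units; within the scatter). For compound 3 the estimated value is 8000 nM, with an expected range from 3000 nM to 20000 nM.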

Compound 3, half-maximal inhibitory concentration: 12300 nM
Compound 3: middle estimate off by 1.5-fold (0.19 log units), on the low side; the range from low to high includes it.
By their numbers in this assay, from the lowest: compounds 2, 1 and 3 (each within the scatter of the next, the first and the last beyond it).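

In this assay, going by these compounds alone, putting 2-nitrophenyl in place of 4-(dimethylamino)phenyl on a double-bonded chain carbon bound to a double-bonded chain carbon gives a 2.0-fold higher number from compound 2 to compound 3 (0.31 log units; beyond the scatter) and is the only step at this position that passes the scatter, and that only modestly. Putting the same group in place of 4-bromophenyl gives a 1.0-fold higher number from compound 1 to compound 3 (0.01 log units; within the scatter) and so does not separate 2-nitrophenyl from 4-bromophenyl, a comparison the first two compounds could not offer. Within the data shown here, three quite different substituted phenyl groups at this place therefore span only a narrow band of numbers, with compound 1 within the scatter of both compound 2 and compound 3, so the one separated pair does not amount to a trend.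

The compounds shown leave open whether the nitro group would read the same as 4-nitrophenyl, and how an unsubstituted phenyl, a carboxylic acid on the ring or a primary amine would compare at this place. Nothing available on these compounds bears on what lies behind the numbers.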